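This account rests on a few compounds, and the source may have more. Where it says the series, first, only, none or still open, it means among the compounds named here.

Compound 3 `COc1cc(-c2ccnc3cc(-c4cn(C)c5ccccc45)nn23)cc(OC)c1OC` is the starting point of this step. In a functional assay on A549 cells (Homo sapiens) for inhibition, read by CCK-8 assay, with a stated time of 48 h (a higher number here means a weaker inhibitor, a lower number a stronger inhibitor), compound 3 gives 1340 nM, the highest of the two values known as numbers. Going by the values given here, its nearest neighbour is compound 1 `COc1cc(-c2ccnc3cc(-c4cn(CO)c5ccccc45)nn23)cc(OC)c1OC`, which in this assay gives 167 nM, and the single change between them produces an 8.0-fold higher number from compound 1 to compound 3 (0.90 log units; beyond the scatter). Compound 2 `COc1cc(-c2ccnc3cc(-c4cccc(C#N)c4)nn23)cc(OC)c1OC` shows in this assay only a limit, > 10000 nM, which is the limit of > 10000 nM in this assay, at which 1 of the 3 values shown sits. Among the compounds with values here, from there the one measured step that bears on what follows runs to compound 3: an at least 7.4-fold lower number from compound 2 to compound 3 (0.87 log units; beyond the scatter), where the 1-methyl-1H-indol-3-yl replaced the 3-cyanophenyl. Compound 4 `COc1ccc(-c2cc3nccc(-c4cc(OC)c(OC)c(OC)c4)n3n2)cc1N` has not yet been measured; it differs from compound 3 by 3-amino-4-methoxyphenyl in place of 1-methyl-1H-indol-3-yl on an aromatic carbon. Since moving from a substituted phenyl to the indolyl gave a large gain between compound 2 and compound 3, returning to a substituted phenyl is expected to cost potency, so a 3.0-fold higher number from compound 3 to compound 4 (0.47 log units; beyond the scatter) is anticipated. Compound 4 is therefore estimated at 4000 nM, expected within 1000 nM to 20000 nM, with a real chance that only a limit is reported.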

Compound 4, half-maximal inhibitory concentration: 138 nM
Beside the measured number, compound 4's estimate is 29-fold (1.46 log units) above it; the measured number lies below the stated range.
By their numbers in this assay, from the lowest: compounds 4 and 1 (each within the scatter of the next); then compound 3. At a limit, above all of these: compound 2.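

In this assay, the only phenyl seen earlier at this aromatic carbon was the 3-cyanophenyl of compound 2, whereas 3-amino-4-methoxyphenyl in place of 1-methyl-1H-indol-3-yl gives a 9.7-fold lower number from compound 3 to compound 4 (0.99 log units; beyond the scatter), so an indole is not required here. Compound 2 holds only a limit, not a number: the limit of > 10000 nM in this assay, at which 1 of the 4 values shown sits. Among the compounds shown, the substituents on the phenyl therefore matter greatly, with 3-amino-4-methoxyphenyl in place of 3-cyanophenyl giving an at least 72-fold lower number from compound 2 to compound 4 (1.86 log units; beyond the scatter).

Because that step swaps the nitrile for both an amino and a methoxy group, the compounds shown do not tell which of the two carries the gain. From the compounds shown here alone, it also remains open whether a dimethylamino group or an acetamide in place of the amino group would keep this result.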